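Enlarging the para group: tert-butyl to neopentyl

A few compounds are considered here, and "the series" means these few. Any claim that something is new, unique, unknown or untested is made for them only; others in the source may bear on it.

Three ureas have been measured in an assay on microsomes for inhibition of acyl-CoA:cholesterol acyltransferase (Oryctolagus cuniculus); a lower number here means a stronger inhibitor, a higher number a weaker inhibitor. Compound 1 `Cc1ccccc1C1(CNC(=O)Nc2c(C(C)C)cccc2C(C)C)CCCC1` gives 17 nM, compound 2 `CC(C)c1ccc(C2(CNC(=O)Nc3c(C(C)C)cccc3C(C)C)CCCC2)cc1` gives 48 nM, and compound 3 `CC(C)c1cccc(C(C)C)c1NC(=O)NCC1(c2ccc(C(C)(C)C)cc2)CCCC1` gives 63 nM. Compound 3 thus carries the highest of the three numbers, but its gap to compound 2 lies within the scatter, while the step of a 3.7-fold higher number from compound 1 to compound 3 (0.57 log units; beyond the scatter) lies beyond it. Compound 4 `CC(C)c1cccc(C(C)C)c1NC(=O)NCC1(c2ccc(CC(C)(C)C)cc2)CCCC1` differs from compound 3 by neopentyl in place of tert-butyl on an aromatic carbon. The closest measured precedent is the step of a 1.3-fold higher number from compound 2 to compound 3 (0.12 log units; within the scatter), which enlarged the group at the same place without a change beyond the scatter; the step of a 2.8-fold higher number from compound 1 to compound 2 (0.45 log units; beyond the scatter) concerned a different place on the ring. A further enlargement of the same kind is therefore expected to alter this assay little, a 1.3-fold higher number from compound 3 to compound 4 (0.10 log units; within the scatter). Compound 4 is estimated at 80 nM, with a range from 30 nM to 220 nM.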

Compound 4, half-maximal inhibitory concentration: 159 nM
Estimate against measurement, compound 4: 2.0-fold (0.30 log units) below; the measured number falls inside the stated range.
By their numbers in this assay, from the lowest: compound 1; then compounds 2 and 3 (each within the scatter of the next); then compound 4.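

On an aromatic carbon para to a large group, going from tert-butyl to neopentyl moves the number beyond the scatter (a 2.5-fold higher number from compound 3 to compound 4 (0.40 log units; beyond the scatter)), although the earlier isopropyl to tert-butyl change did not. Neopentyl also stands clear of isopropyl (a 3.3-fold higher number from compound 2 to compound 4 (0.52 log units; beyond the scatter)), and replacing 2-methylphenyl with 4-neopentylphenyl gives the widest gap of the set (a 9.4-fold higher number from compound 1 to compound 4 (0.97 log units; beyond the scatter)). The data offer no explanation for these differences. Still open, as far as these compounds go, is whether a longer chain such as n-hexyl at this place would raise the number further, and how a methoxy group there would compare.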